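This account rests on a few compounds, and the source may have more. Where it says the series, first, only, none or still open, it means among the compounds named here.

Of the compounds shown here, two sharing one core have been measured in a functional assay on KB cells (Homo sapiens) for inhibition, read by MTT assay, with a stated time of 24 h, tested at 5 uM; a higher number here means more inhibition of growth at the concentration tested, a lower number less inhibition of growth. Compound 1 `CS(=O)(=O)c1ccc(-c2cnc3[nH]cc(-c4nnc(-c5ccccc5)o4)c(=O)c3c2)cc1` gives 4.38% in this assay, and compound 2 `CS(=O)(=O)c1ccc(-c2cnc3[nH]cc(-c4nnc(-c5ccc(Cl)cc5)o4)c(=O)c3c2)cc1` gives 2.15%. For the measured compounds named here, the only step between them, a number 2.2 percentage points lower from compound 1 to compound 2 (within the scatter), shows that putting chloro in place of hydrogen on an aromatic carbon changes little. Compound 2 thus stands within the scatter of compound 1, and neither compound inhibits growth to any clear extent at the concentration tested.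

Compound 3 `Cc1cccc(-c2nnc(-c3c[nH]c4ncc(-c5ccc(S(C)(=O)=O)cc5)cc4c3=O)o2)c1` arises from compound 2 through the change (3-methylphenyl in place of 4-chlorophenyl on an aromatic carbon). Going by the values given here, the group swapped here is the same one that the single measured step, a number 2.2 percentage points lower from compound 1 to compound 2 (within the scatter), altered without leaving the scatter, so a further exchange of that group gives no reason to expect a larger movement. The expected step from compound 2 to compound 3 is a number 0.9 percentage points higher from compound 2 to compound 3 (within the scatter), which is no step beyond the scatter. Compound 3 is therefore estimated to give 3% in this assay, within a range from -5% to 12%.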

Compound 3, percent growth inhibition at one concentration: 3.7%
Estimate against measurement, compound 3: 0.7 percentage points below, within the range that was stated.
By their numbers in this assay, from the lowest: compounds 2, 3 and 1 (each within the scatter of the next).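

At this position, on the aromatic carbon of the five-membered ring with 2 nitrogen and 1 oxygen, the exchange of 4-chlorophenyl for 3-methylphenyl gives a number 1.6 percentage points higher from compound 2 to compound 3 (within the scatter) in this assay and so does not separate the two compounds. Set against the plain phenyl group of compound 1, the added methyl gives a number 0.7 percentage points lower from compound 1 to compound 3 (within the scatter) and is likewise no real change, so a methyl on this ring now joins the chloro of compound 2 in leaving the reading where the plain phenyl group has it, and across these three compounds growth inhibition stays low at the concentration tested. Nothing available here explains why these numbers stay together.

From the compounds shown here alone, whether an amine or a carboxylic acid on this phenyl ring, or a longer chain in place of the ring, would raise growth inhibition clearly above this low level remains open. So does the question of whether a change on the shared core, rather than on this ring, would move the number beyond the usual scatter.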